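Thiosemicarbazone series: demethylation of the aryl ether

The compounds below may be only part of what the source reports. "The series", "measured", "known", "first", "only" and "open" are said of these compounds alone.

Within the data shown here, compound 3 `COc1ccc(/C=N\NC(=S)NC(C)(C)CCC[C@](C)(O)[C@@H]2CC=C(C)CC2)cc1` gives 6500 nM in a functional assay on OVCAR-3 cells (Homo sapiens) for cytotoxicity, read by sulforhodamine B assay (on this read-out lower numbers stand for stronger inhibition of growth and higher numbers for weaker inhibition of growth), the second highest of the three numbers measured so far. Compound 1 `CC1=CC[C@@H]([C@@](C)(O)CCCC(C)(C)NC(=S)NN)CC1` gives 17200 nM and compound 2 `CC1=CC[C@@H]([C@@](C)(O)CCCC(C)(C)NC(=S)N/N=C\c2ccc(C)cc2)CC1` gives 6020 nM; the measured steps are a 2.6-fold lower number from compound 1 to compound 3 (0.42 log units; beyond the scatter) and a 2.9-fold lower number from compound 1 to compound 2 (0.46 log units; beyond the scatter), while a 1.1-fold higher number from compound 2 to compound 3 (0.03 log units; within the scatter). Compound 4 `CC1=CC[C@@H]([C@@](C)(O)CCCC(C)(C)NC(=S)N/N=C\c2ccc(O)cc2)CC1` differs from compound 3 by hydrogen in place of methyl on an oxygen on an aromatic ring. Among the measured compounds shown here, no measured step touches this oxygen directly; the only aryl change seen, a 1.1-fold higher number from compound 2 to compound 3 (0.03 log units; within the scatter), stayed within the scatter, and the larger steps concern the replacement of the terminal nitrogen. In this assay the expected step is therefore no change at the digits printed from compound 3 to compound 4 (within the scatter), not beyond the scatter. Compound 4 is estimated at 6500 nM, with a range of 2800 nM to 15000 nM.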

Compound 4, concentration for 50% growth inhibition: 6230 nM
Estimate against measurement, compound 4: 1.0-fold (0.02 log units) above, within the range that was stated.
By their numbers in this assay, from the lowest: compounds 2, 4 and 3 (each within the scatter of the next); then compound 1.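

In (this assay), hydrogen in place of methyl on this oxygen leaves the 4-hydroxyphenyl and 4-methoxyphenyl compounds unseparated (a 1.0-fold lower number from compound 3 to compound 4 (0.02 log units; within the scatter)), and hydroxy in place of methyl on the aromatic carbon reads the same (a 1.0-fold higher number from compound 2 to compound 4 (0.01 log units; within the scatter)). The free hydroxy form keeps the gap to the terminal-nitrogen compound seen for the other two aryl compounds (a 2.8-fold lower number from compound 1 to compound 4 (0.44 log units; beyond the scatter)). Nothing measured on hand explains this flat read-out.

As far as these compounds go, whether an amine or a carboxylic acid on that aromatic carbon would stay within the same band remains open.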